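The compounds below may be only part of what the source reports. "The series", "measured", "known", "first", "only" and "open" are said of these compounds alone.

Compound 1 `NS(=O)(=O)c1ccc(N2N=C(c3ccc(OCc4ccccc4)cc3)CC2c2ccccc2)cc1` in an ADME assay on Vero 76 cells (Chlorocebus sabaeus) for cytotoxicity, read by MTT assay, with a stated time of 96 h (on this read-out lower numbers stand for higher toxicity in this test and higher numbers for lower toxicity in this test), gives a result that is a limit of the assay, > 100000 nM. Compound 2 `NS(=O)(=O)c1ccc(N2N=C(c3ccc(Oc4ccccc4)cc3)CC2c2ccccc2)cc1` in this assay gives 85000 nM, while compound 3 `NS(=O)(=O)c1ccc(N2N=C(c3ccc(OCc4ccccc4)cc3)CC2c2ccccc2Cl)cc1` gives 92000 nM; the numbers of compound 2 and compound 3 lie within the scatter of each other. The step of an at least 1.1-fold lower number from compound 1 to compound 2 (0.07 log units; that floor lies within the scatter) and the step of an at least 1.0-fold lower number from compound 1 to compound 3 (0.03 log units; that floor lies within the scatter) both begin at the limit of > 100000 nM in this assay, at which 1 of the 3 values shown sits, so only floors are known, and each floor is within the scatter. Compound 4 `NS(=O)(=O)c1ccc(N2N=C(c3ccc(Oc4ccccc4)cc3)CC2c2cccc(F)c2)cc1` differs from compound 2 by fluoro in place of hydrogen on an aromatic carbon. Among the measured compounds shown here, no measured step tests this change directly, and the two known steps are small, so no step beyond the scatter is expected in this assay. Compound 4 is therefore estimated at 85000 nM, between 40000 nM and 180000 nM. The expected step is no change at the digits printed from compound 2 to compound 4 (within the scatter), within the scatter.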

Compound 4, half-maximal cytotoxic concentration: 28000 nM
The estimate for compound 4 lay 3.0-fold (0.48 log units) above the measured number; the measured number lies below the stated range.
By their numbers in this assay, from the lowest: compound 4; then compounds 2 and 3 (each within the scatter of the next). At a limit, above all of these: compound 1.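

In this assay, among the compounds shown here, the step of a 3.0-fold lower number from compound 2 to compound 4 (0.48 log units; beyond the scatter) is the first to lie beyond the scatter. For the compounds shown here, it shows that this place on the ring is not indifferent in this test, since phenyl to 3-fluorophenyl moves the number towards higher toxicity, though only this one pair tests it. The earlier halogen step, an at least 1.0-fold lower number from compound 1 to compound 3 (0.03 log units; that floor lies within the scatter), gave only a floor, as it starts from a limit: the limit of > 100000 nM in this assay, at which 1 of the 4 values shown sits.

On these data alone, whether chloro, methoxy or an amine at this place would act alike remains open. So does whether fluoro would do the same with a benzyl group on the oxygen.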